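The source may hold more compounds than are shown below. What is called first, only, known or untested is meant among the compounds shown, and "the series" means these compounds.

Of the compounds shown here, two have numbers so far in a functional assay on HCT-116 cells (Homo sapiens) for cytotoxicity, read by crystal violet staining, with a stated time of 7 days; a higher number here means a weaker inhibitor, a lower number a stronger inhibitor. Compound 1 (`COc1cc(/C=C/C(=O)C2=Cc3cc(OC)ccc3OC2)cc(OC)c1`) gives 330 nM. Compound 2 (`COc1cc(OC)cc(C(=O)/C=C/C2=Cc3cc(OC)ccc3OC2)c1`) gives 35500 nM, the higher of the two numbers and beyond the scatter from compound 1, which makes compound 2 the weaker inhibitor of this pair. Compound 3 (`COc1cc(OC)cc(C(=O)/C=C/C2=Cc3cc(Br)ccc3OC2)c1`) differs from compound 2 at one place: bromo in place of methoxy on an aromatic carbon. The change is bromo in place of methoxy on an aromatic carbon. Among the compounds with values here, no measured pair shows a change of this kind, so the expectation rests on thin ground. The estimated step, a 2.0-fold lower number from compound 2 to compound 3 (0.29 log units; within the scatter), is expected to be a modest drop in the number, one that may not clear the scatter. For compound 3 the expected value is 18000 nM, with an estimated range of 4000 nM to 60000 nM.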

Compound 3, half-maximal inhibitory concentration: 3400 nM
The estimate for compound 3 lay 5.3-fold (0.72 log units) above the measured number; the whole stated range lies above it.
By their numbers in this assay, from the lowest: compound 1; then compound 3; then compound 2.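

In this assay, within the data shown here, the aromatic carbon carrying methoxy in compound 2 is not a silent site: bromo in place of methoxy gives a 10-fold lower number from compound 2 to compound 3 (1.02 log units; beyond the scatter) as the first measured step. The step shows that methoxy is not needed at this position for the number to fall, and that a single atom there can move the read-out beyond the scatter. It rests on one pair, on the background of compound 2 alone, and nothing at hand bears on what lies behind it.

Going by these compounds, whether the same change would carry over to the core of compound 1 remains open. Also open, on these data alone, is whether the step is particular to bromo, a question that chloro, an amine or a plain hydrogen on this carbon would address.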